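A few compounds are considered here, and "the series" means these few. Any claim that something is new, unique, unknown or untested is made for them only; others in the source may bear on it.

The measured compounds, and what each gave in a functional assay on HT-29 cells (Homo sapiens) for antiproliferative activity, read by sulforhodamine B assay, with a stated time of 48 h; a higher number here means a weaker inhibitor, a lower number a stronger inhibitor:

Compound 1, `CCN1CCN(c2ccc(S(=O)(=O)Oc3cccc(F)c3)cc2)C1=O`, gives > 100000 nM, which is a limit of the assay and not a number.
Compound 2, `CCN1CCN(c2ccc(S(=O)(=O)Oc3cccc(Cl)c3)cc2)C1=O`, gives 6800 nM.
Compound 3, `CCCN1CCN(c2ccc(S(=O)(=O)Oc3ccc(F)cc3)cc2)C1=O`, gives 23000 nM.

Compound 4, `CCCN1CCN(c2ccc(S(=O)(=O)Oc3ccc(Cl)cc3)cc2)C1=O`, has not yet been measured in this assay.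

Compound 2 differs from compound 1 by chloro in place of fluoro on an aromatic carbon. That change gave an at least 14-fold lower number from compound 1 to compound 2 (1.16 log units; beyond the scatter). The step is stated only as a lower bound because compound 1 sits at the limit of > 100000 nM in this assay, at which 1 of the 3 values shown sits.

Compound 4 differs from compound 3 by chloro in place of fluoro on an aromatic carbon. This is the same kind of change, not the same one: in the pair compound 1 and compound 2 the exchanged atom sits meta to a large group, whereas in the pair compound 3 and compound 4 it sits para to a large group. How the core of compound 3 differs from the core of compound 1 is not broken down here.

Among the measured compounds, compound 3 gives the highest number in this assay. Going by the values given here, since the only measured example of this kind of change, from compound 1 to compound 2, gave a large drop in the number, a drop is expected here as well, though its size is uncertain because the first step rests on the limit of > 100000 nM in this assay, at which 1 of the 3 values shown sits, and is known only as a bound. For compound 4 the expected step is a 5.0-fold lower number from compound 3 to compound 4 (0.70 log units; beyond the scatter). Compound 4 is therefore estimated at 4600 nM, with a likely range from 1500 nM to 15000 nM.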

Compound 4, half-maximal inhibitory concentration: 15000 nM
For compound 4 the middle estimate is 3.3-fold (0.51 log units) below the measured one; measured number inside the range.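

In this assay, chloro in place of fluoro does not bring the same result on the two cores, so the earlier step cannot simply be carried from one to the other: the same change on two cores in this assay, an at least 14-fold lower number (1.16 log units; beyond the scatter) from compound 1 to compound 2 and a 1.5-fold lower number (0.19 log units; within the scatter) from compound 3 to compound 4, at least 9.5-fold (0.98 log units) apart, beyond the scatter of two such steps. On the core of compound 3, with the exchanged atom para to a large group, the new step is a 1.5-fold lower number from compound 3 to compound 4 (0.19 log units; within the scatter), so in this pair the exchange shows no effect that can be told apart from the scatter. This does not show what separates the two results, since the pairs differ both in the core and in where the exchanged atom sits on the ring, and the size of the earlier step remains only a bound, with compound 1 standing at a limit of the assay and not at a number: the limit of > 100000 nM in this assay, at which 1 of the 4 values shown sits.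

The compounds shown leave open how fluoro and chloro would compare if the exchanged atom sat at the same place on both cores, which would separate the effect of the core from the effect of position. They also leave open whether a bromo, methoxy or trifluoromethyl group on that ring, or a longer chain on the core, would change the number in this assay.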